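Trifluoromethyl in Place of Fluoro: an Expected Small Step

This account rests on a few compounds, and the source may have more. Where it says the series, first, only, none or still open, it means among the compounds named here.

Compound 3 `Cc1c(C(=O)Nc2c(F)cc(-c3cccc(F)c3)cc2F)nc2ccc(F)cc2c1C(=O)O` stands lowest of the three measured numbers in a functional assay on A-375 cells (Homo sapiens) for antiproliferative activity, read by MTT assay, with a stated time of 24 h, tested at 0.41 ug/mL (a lower number here means a weaker effect, a higher number a stronger effect of the compound at the concentration tested), at 3.02%. Compound 2 `CCc1ccc2nc(C(=O)Nc3c(F)cc(-c4cccc(F)c4)cc3F)c(C)c(C(=O)O)c2c1` gives 6.13%, and compound 1 `Cc1c(C(=O)Nc2c(F)cc(-c3cccc(F)c3)cc2F)nc2ccc(C(F)(F)F)cc2c1O` gives 16.5%. Going by the values given here, the one single-point step measured, a number 3.1 percentage points lower from compound 2 to compound 3 (within the scatter), was within the scatter. Compound 4 `Cc1c(C(=O)Nc2c(F)cc(-c3cccc(F)c3)cc2F)nc2ccc(C(F)(F)F)cc2c1C(=O)O` differs from compound 3 in that (trifluoromethyl in place of fluoro on an aromatic carbon). That earlier step is the only one bearing on the same position; it was small, so no step beyond the scatter is expected in this assay here either. Among the compounds with values here, compound 1 also carries the trifluoromethyl, but its remaining difference from compound 4 was not stepped on its own, so its value shows only that a higher number is reachable. Compound 4 is therefore expected at 6%, between 0% and 17%. The step of a number 3 percentage points higher from compound 3 to compound 4 (within the scatter) that this estimate means is expected to stay within the scatter.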

Compound 4, a percentage reported as inhibition, at one concentration (the size of the read-out at that concentration, not a potency): 7.82%
The estimate for compound 4 lay 1.8 percentage points below the measured number; the measured number falls inside the stated range.
By their numbers in this assay, from the lowest: compounds 3, 2, 4 and 1 (each within the scatter of the next, the first and the last beyond it).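

At this aromatic carbon, trifluoromethyl in place of fluoro gives a number 4.8 percentage points higher from compound 3 to compound 4 (within the scatter), and trifluoromethyl in place of ethyl gives a number 1.7 percentage points higher from compound 2 to compound 4 (within the scatter), so the three groups are not told apart in this assay. The change from hydroxy to carboxy, not stepped on its own before, gives a number 8.7 percentage points lower from compound 1 to compound 4 (within the scatter), so it is not told apart either. No evidence on hand bears on these results. The compounds shown leave open whether an amine or a longer chain at this carbon, or an amide in place of the carboxy, would give a step beyond the scatter.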